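The source may hold more compounds than are shown below. What is called first, only, known or untested is meant among the compounds shown, and "the series" means these compounds.

In a functional assay on HEK293 cells for negative allosteric modulation of metabotropic glutamate receptor 5 (Rattus norvegicus), read by FLIPR and calcium flux, with a stated time of 170 s (a higher number here means a weaker inhibitor, a lower number a stronger inhibitor), compound 1 `Clc1ccnc(COc2cc3n(n2)CCCC3)c1` gives only a limit, > 10000 nM, so it provides no number. Among the compounds with values here, compound 2 `N#Cc1ccc(COc2cc3n(n2)CCCC3)nc1` is the one compound here with a measured value, giving 316 nM in this assay. The other value shown, that of compound 1, is a limit (the limit of > 10000 nM in this assay, at which 1 of the 2 values shown sits). Compound 3 `CC(=O)c1ccc(COc2cc3n(n2)CCCC3)nc1` has not yet been measured; its change from compound 2 is acetyl in place of cyano on an aromatic carbon. Both groups carry one acceptor, so a step from compound 2 to compound 3 of a 2.2-fold higher number from compound 2 to compound 3 (0.35 log units; beyond the scatter) is expected, a modest loss near the scatter. Compound 3 is estimated at 700 nM, with a range from 200 nM to 2500 nM.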

Compound 3, half-maximal inhibitory concentration: "not active" (no number reported)
The entry for compound 3 holds no number; no gap can be computed for the estimate.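

Within the data shown here, compound 3 is reported only as "not active", with no number, so no step from compound 2 to compound 3 can be read in this assay. Nothing measured here explains this result. The compounds shown leave open how large a change, in numbers, acetyl brings in place of cyano.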